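The source may report more compounds than this note shows. Statements on the series, on what has been measured and on what is new or still open speak of the compounds shown alone.

Measured so far in a functional assay on IMR-32 cells (Homo sapiens) for cytotoxicity, read by sulforhodamine B assay, with a stated time of 48 h; on this read-out higher numbers stand for weaker inhibition and lower numbers for stronger inhibition:
- compound 1, `COc1ccccc1/C=C/C(=O)/C=C/C1=C(C)CCCC1(C)C`: 19200 nM
- compound 2, `CC1=C(/C=C/C(=O)/C=C/C=C/c2ccccc2)C(C)(C)CCC1`: 23400 nM

Within the data shown here, both measured compounds share the same core and differ in two places at once, so their pairing gives no single-change step. Compound 2 has the highest of the two numbers; its nearest neighbour is compound 1, and the gap between compound 2 and compound 1 falls within the scatter, so no order between them can be stated.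

Compound 3, `COc1ccccc1/C=C/C=C/C(=O)/C=C/C1=C(C)CCCC1(C)C`, is not yet measured. It is reached from compound 2 by the change (methoxy in place of hydrogen on an aromatic carbon). Among the measured compounds shown here, no step between measured compounds covers this change, so the expectation rests only on where compound 2 stands. The step from compound 2 to compound 3 is expected to be small, with no direction beyond the scatter, a 1.1-fold lower number from compound 2 to compound 3 (0.05 log units; within the scatter). Because compound 2 gives 23400 nM in this assay, compound 3 is estimated at 21000 nM, within a range of 8000 nM to 55000 nM.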

Compound 3, half-maximal inhibitory concentration: 72400 nM
Estimate against measurement, compound 3: 3.4-fold (0.54 log units) below, outside the stated range (above it).
By their numbers in this assay, from the lowest: compounds 1 and 2 (each within the scatter of the next); then compound 3.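

In this assay, among these compounds, the change from phenyl to 2-methoxyphenyl gives a 3.1-fold higher number from compound 2 to compound 3 (0.49 log units; beyond the scatter) and so provides the first single-change step, modest in size but beyond the scatter. It shows that, on this core, the aromatic carbon ortho to a large group is not indifferent to substitution: methoxy in place of hydrogen there goes with weaker inhibition, which the two-place difference between compound 1 and compound 2 could not show. Among the compounds shown here, no measurement on these compounds speaks to the origin of this step.

Still open, on these data alone, is whether a hydroxyl, a fluorine or a dimethylamino group at this same carbon would move the number in the same direction. Also open, as far as these compounds go, is whether methoxy elsewhere on the aromatic ring, or the same change on the core of compound 1, would give a step of similar size.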